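The source may report more compounds than this note shows. Statements on the series, on what has been measured and on what is new or still open speak of the compounds shown alone.

Measured compounds in a functional assay on CHO cells for agonist activity at Alpha-1D adrenergic receptor (Homo sapiens), read by FLIPR and calcium flux; on this read-out higher numbers stand for an effect only at larger amounts of compound and lower numbers for an effect already at smaller amounts: compound 1 `Cc1n[nH]cc1-c1cccc2c1CCC2c1ncc[nH]1` gives 634 nM; compound 2 `c1cc(-c2ccn[nH]2)c2c(c1)C(c1ncc[nH]1)CC2` gives 336 nM.

Compound 1 stands highest of the two numbers, but the step of a 1.9-fold lower number from compound 1 to compound 2 (0.28 log units; within the scatter) lies within the scatter, so the two are not separated. Compound 3 `Cn1nccc1-c1cccc2c1CCC2c1ncc[nH]1` is not yet measured; it differs from compound 1 by 1-methyl-1H-pyrazol-5-yl in place of 3-methyl-1H-pyrazol-4-yl on an aromatic carbon. Among the compounds with values here, the one measured step, from compound 1 to compound 2, also exchanged one pyrazole for another and stayed within the scatter; no measured step covers a methyl on a pyrazole nitrogen. The expected step is therefore a 1.1-fold higher number from compound 1 to compound 3 (0.04 log units; within the scatter), none beyond the scatter, with a wide range. Compound 3 is estimated at 700 nM, between 200 nM and 2500 nM.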

Compound 3, half-maximal effective concentration: > 10000 nM
Compound 3 was reported as a limit (the forecaster's own chance of this, stated with the estimate: 10%); at least 14-fold (1.15 log units) between middle value and limit.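

The reading for compound 3 is a limit and not a number: the limit of > 10000 nM in this assay, at which 1 of the 3 values shown sits. On this aromatic carbon, pyrazoles are thus not interchangeable: 1-methyl-1H-pyrazol-5-yl gives an at least 15-fold higher number from compound 1 to compound 3 (1.19 log units; beyond the scatter), and methyl in place of hydrogen on an aromatic nitrogen gives an at least 29-fold higher number from compound 2 to compound 3 (1.47 log units; beyond the scatter). The entering group carries 0 hydrogen-bond donors, against 1 in 3-methyl-1H-pyrazol-4-yl, but this count alone does not establish the cause.

Still open, from the compounds shown here alone, is whether ethyl on that pyrazole nitrogen behaves like methyl. Also open, going by these compounds, is whether an amine on this aromatic carbon would give a number short of the limit.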